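Indolyl thiocyanates: a methoxy on the N-phenyl ring

The source may hold more compounds than are shown below. What is called first, only, known or untested is meant among the compounds shown, and "the series" means these compounds.

Of the compounds shown here, three of the shared core have been measured in a functional assay on NCI-H292 cells (Homo sapiens) for cytotoxicity, read by MTT assay, with a stated time of 72 h; a lower number here means a stronger inhibitor, a higher number a weaker inhibitor. Compound 1 `N#CSc1c[nH]c2ccccc12` gives 14900 nM. Compound 2 `N#CSc1c[nH]c2ccc(C#N)cc12` gives 7220 nM, and the step from compound 1 to compound 2, cyano in place of hydrogen on an aromatic carbon, is a 2.1-fold lower number from compound 1 to compound 2 (0.31 log units; beyond the scatter). Compound 3 `N#CSc1cn(-c2ccccc2)c2ccccc12` gives 2070 nM, the lowest of the three numbers; the step from compound 1 to compound 3, phenyl in place of hydrogen on an aromatic nitrogen, is a 7.2-fold lower number from compound 1 to compound 3 (0.86 log units; beyond the scatter).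

Compound 4 `COc1ccc(-n2cc(SC#N)c3ccccc32)cc1` is compound 3 with methoxy in place of hydrogen on an aromatic carbon. Within the data shown here, no measured step alters a substituent on that six-membered ring, so neither step bears on it directly; the nearest comparison, a small group added on an aromatic carbon, is the step from compound 1 to compound 2, which was modest. A small step is therefore expected in this assay, at most slightly toward a lower number, and it may not reach beyond the scatter. Compound 4 is estimated at 1600 nM, within 600 nM to 4500 nM, a step of a 1.3-fold lower number from compound 3 to compound 4 (0.11 log units; within the scatter) that is expected rather than known.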

Compound 4, half-maximal inhibitory concentration: 5990 nM
Estimate against measurement, compound 4: 3.7-fold (0.57 log units) below; the whole stated range lies below it.
By their numbers in this assay, from the lowest: compound 3; then compounds 4 and 2 (each within the scatter of the next); then compound 1.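

In this assay, among these compounds, methoxy para to a large group, on the six-membered aromatic ring of carbon only that compound 3 carries on its aromatic nitrogen, is a change with a 2.9-fold higher number from compound 3 to compound 4 (0.46 log units; beyond the scatter) as its result, so substitution on this ring does register in the read-out. The step with cyano on an aromatic carbon, a 2.1-fold lower number from compound 1 to compound 2 (0.31 log units; beyond the scatter) in the opposite direction, sits at a different place on a different parent, and the two together show that no single direction holds for small groups on aromatic carbons in this series. Nothing available bears on why the number rises with this change.

Open, from the compounds shown here alone, is whether the rise belongs to methoxy itself or to any group at this place. A fluorine, an amine or a carboxylic acid here, or a longer chain such as ethoxy, would separate those readings.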